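A Nitrophenyl Replaces the Benzothiazole Arm

This account rests on a few compounds, and the source may have more. Where it says the series, first, only, none or still open, it means among the compounds named here.

Two analogues of a shared core carry different groups on an aromatic nitrogen. For compound 1 `COc1ccc(/C=C\C(=O)O)c(OCc2cn(-c3cccnc3Cl)nn2)c1CC=C(C)C` the entry in a functional assay on T47D cells (Homo sapiens) for cytotoxicity, read by MTT assay, with a stated time of 24 h (on this read-out lower numbers stand for stronger inhibition and higher numbers for weaker inhibition), reads "not determined" (no result reported), so no number is recorded. Among the compounds with values here, compound 2 `COc1ccc(/C=C\C(=O)O)c(OCc2cn(-c3nc4ccccc4s3)nn2)c1CC=C(C)C` is thus the only compound with a number in this assay; in this assay compound 2 gives 17200 nM, a weak effect. Compound 3 `COc1ccc(/C=C\C(=O)O)c(OCc2cn(-c3cccc([N+](=O)[O-])c3)nn2)c1CC=C(C)C` differs from compound 2 by a single exchange: 3-nitrophenyl in place of 1,3-benzothiazol-2-yl on an aromatic nitrogen. Within the data shown here, no measured pair shows how such an exchange moves this assay, so nothing beyond the single value of compound 2 supports a direction. The step of a 1.2-fold higher number from compound 2 to compound 3 (0.07 log units; within the scatter) is expected to remain within the usual scatter, with no clear direction. Compound 3 is therefore estimated at 20000 nM in this assay, with a range from 6000 nM to 60000 nM.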

Compound 3, half-maximal inhibitory concentration: 15400 nM
Beside the measured number, compound 3's estimate is 1.3-fold (0.11 log units) above it; measured number inside the range.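

Within the data shown here, the exchange of 1,3-benzothiazol-2-yl for 3-nitrophenyl on an aromatic nitrogen gives a 1.1-fold lower number from compound 2 to compound 3 (0.05 log units; within the scatter) in this assay, the first measured step at this position. A group with a five-membered and a six-membered aromatic ring and a group with a single six-membered aromatic ring therefore read alike here, each with the same count of heavy atoms and hydrogen-bond acceptors. Nothing measured on either group speaks to why the two read alike.

Both groups are aromatic, so the compounds shown leave open whether an amine, a carboxylic acid or a longer chain on this aromatic nitrogen would read differently. With no number for compound 1, its group adds nothing to this comparison.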